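The source may report more compounds than this note shows. Statements on the series, on what has been measured and on what is new or still open speak of the compounds shown alone.

Measured in an ADME assay on the whole organism for pharmacokinetics, with Rattus norvegicus as the target; on this read-out higher numbers stand for fast clearance and lower numbers for slow clearance:
Compound 1 `CC#C[C@@H](Cc1nnn[nH]1)c1ccc(OCc2ccc3sc(F)c(-c4ccccc4C)c3c2)cc1`: 23.2 mL/min/kg
Compound 2 `CC#C[C@@H](Cc1nnn[nH]1)c1ccc(OCc2ccc3scc(-c4ccc(OCCCS(C)(=O)=O)cc4C)c3c2)cc1`: 65 mL/min/kg

Of these two, compound 1 has the lower number, and compound 2 stands higher by more than the usual scatter. Compound 3 `CC#C[C@@H](Cc1nnn[nH]1)c1ccc(OCc2ccc3sc(Cl)c(-c4ccccc4C)c3c2)cc1` keeps the core of compound 1 and carries one change, chloro in place of fluoro on an aromatic carbon. Going by the values given here, no two measured compounds differ in one place only, so the data offer no direct guide to the size of this swap. No step beyond the scatter is expected in this assay, in either direction. The expected change is small, a 1.1-fold lower number from compound 1 to compound 3 (0.04 log units; within the scatter). Compound 3 is estimated at 21 mL/min/kg, with an expected range of 10 mL/min/kg to 45 mL/min/kg.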

Compound 3, clearance: 4.4 mL/min/kg
Compound 3: middle estimate off by 4.8-fold (0.68 log units), on the high side, outside the stated range (below it).
By their numbers in this assay, from the lowest: compound 3; then compound 1; then compound 2.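

In this assay, this halogen swap on the aromatic carbon next to the ring sulfur is not a neutral exchange: chloro in place of fluoro gives a 5.3-fold lower number from compound 1 to compound 3 (0.72 log units; beyond the scatter). Going by these compounds alone, this is the first comparison in the set that differs in one place only, and it shows that a step beyond the scatter can arise at this position even though one heavy atom replaces one heavy atom, with no ring, hydrogen-bond donor, hydrogen-bond acceptor or net charge entering or leaving. No available evidence bears on what lies behind this step.

From the compounds shown here alone, whether bromo, methyl or a nitrile on this same carbon would give a similar number remains open. Going by these compounds, it is also open whether chloro would give a step of this size on the core of compound 2.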